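A few compounds are considered here, and "the series" means these few. Any claim that something is new, unique, unknown or untested is made for them only; others in the source may bear on it.

Measured so far in an ADME assay on microsomes from liver (Rattus norvegicus) for metabolic stability, read by HPLC, using NADPH, with stated times of 5 min and 60 min, tested at 10 uM; a higher number here means faster removal of the compound, a lower number slower removal:
- compound 1 `Cn1cc(-c2cc(NS(C)(=O)=O)ccc2Oc2ccc(F)cc2F)c2cc[nH]c2c1=O` gives < 65 mL/min/kg as a limit, not a number
- compound 2 `Cn1cc(-c2cc(NS(C)(=O)=O)ccc2Oc2cccnc2)c2cc[nH]c2c1=O` gives 350 mL/min/kg as the only exact number

Compound 2 is thus the only exact reference point. The change to compound 3 `Cn1cc(-c2cc(NS(C)(=O)=O)ccc2OC2CCC(F)(F)CC2)c2cc[nH]c2c1=O` is 4,4-difluorocyclohexyl in place of pyridin-3-yl on an oxygen on an aromatic ring and it removes the pyridin-3-yl. Within the data shown here, the one measured step bearing on this is an at least 5.3-fold higher number from compound 1 to compound 2 (0.73 log units; beyond the scatter) and it brought that same pyridin-3-yl in, in place of 2,4-difluorophenyl. Compound 3 carries fluorine on a six-membered ring as compound 1 does, but that ring is non-aromatic, so only part of that step is expected back, as a fall in this assay. The expected move is a 2.7-fold lower number from compound 2 to compound 3 (0.43 log units; beyond the scatter) in this estimate. Compound 3 is estimated at 130 mL/min/kg within a range of 65 mL/min/kg to 320 mL/min/kg.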

Compound 3, clearance: 200 mL/min/kg
Beside the measured number, compound 3's estimate is 1.5-fold (0.19 log units) below it, and the stated range covers the measured number.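

In this assay, 4,4-difluorocyclohexyl in place of pyridin-3-yl gives a 1.8-fold lower number from compound 2 to compound 3 (0.24 log units; within the scatter), so these two groups cannot be told apart on this oxygen. Fluorine on a non-aromatic ring does not match 2,4-difluorophenyl here, as the change between those two groups gives an at least 3.0-fold higher number from compound 1 to compound 3 (0.48 log units; beyond the scatter). Compound 1 stands as a limit, not a number, so the true size of that step stays unknown: the limit of < 65 mL/min/kg in this assay, at which 1 of the 3 values shown sits.

Still open, going by these compounds, is whether the aromatic ring or the fluorine atoms matter more for compound 1. An unsubstituted phenyl or cyclohexyl on the same oxygen would help separate the two.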